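Carbamate to oxane amide on the piperidine nitrogen

A few compounds are considered here, and "the series" means these few. Any claim that something is new, unique, unknown or untested is made for them only; others in the source may bear on it.

The measured compounds are compound 1 `CCOC(=O)N1CCC(NC(=O)Nc2ccc(C(F)(F)F)c(F)c2)CC1` with 5.46, compound 2 `CCOC(=O)N1CCC(NC(=O)Nc2ccc(OC(F)(F)F)c(F)c2)CC1` with 5.94, and compound 3 `O=C(Nc1ccc(C(F)(F)F)cc1)NC1CCN(C(=O)c2ccoc2)CC1` with 3.5, all in a physicochemical assay for lipophilicity, read by HPLC, with a stated time of 90 min, tested at 100 uM; on this read-out lower numbers stand for lower lipophilicity and higher numbers for higher lipophilicity.

Among these three numbers compound 1 stands second highest. Its nearest neighbour is compound 2, which gives 5.94 in this assay, and the furthest is compound 3 with 3.5. Among the measured compounds shown here, the only single-point step available, a number 0.48 log units higher from compound 1 to compound 2 (beyond the scatter), concerns trifluoromethoxy in place of trifluoromethyl on an aromatic carbon.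

Compound 4 `O=C(Nc1ccc(C(F)(F)F)c(F)c1)NC1CCN(C(=O)C2CCCOC2)CC1` is not yet measured. It differs from compound 1 in one place: oxan-3-yl in place of ethoxy on a carbonyl carbon. Cut one bond further out, the change reads ethoxycarbonyl to (oxan-3-yl)carbonyl.

For the measured compounds named here, no measured step bears directly on this change. The step from compound 1 to compound 2 alters a different part of the molecule, and compound 3 differs from compound 1 in two places at once, so the value of compound 3, 3.5, can only be noted. The expectation for compound 4 therefore rests on weak footing, and a step of a number 0.46 log units lower from compound 1 to compound 4 (beyond the scatter) is estimated, likely within or just beyond the scatter. Compound 4 is expected to give 5 in this assay, with a range from 4.3 to 5.7.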

Compound 4, partition coefficient: 3.84
Compound 4: the middle estimate sits 1.16 log units above what was measured; the measured number lies below the stated range.
By their numbers in this assay, from the lowest: compound 3; then compound 4; then compound 1; then compound 2.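

In this assay, the carbonyl carbon on the amide-type ring nitrogen proves to be a place where the read-out responds strongly: oxan-3-yl in place of ethoxy gives a number 1.62 log units lower from compound 1 to compound 4 (beyond the scatter). Among the compounds shown here, this is the first single-place step at that carbonyl carbon, and it is larger than the only earlier step, a number 0.48 log units higher from compound 1 to compound 2 (beyond the scatter), which was made on an aromatic carbon. The number falls even though oxan-3-yl brings more heavy atoms than ethoxy and the same count of hydrogen-bond acceptors, and no evidence is available that accounts for the size of this step.

A single exchange cannot separate what the ring, its oxygen and the loss of the ethoxy oxygen on the carbonyl carbon each contribute, so a cyclohexyl group, a tetrahydrofuranyl group or an oxan-4-yl group at the same place would be needed to tell these apart. From the compounds shown here alone, it also remains open whether the step would keep its size with trifluoromethoxy in place of trifluoromethyl on the aromatic carbon, as in compound 2.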